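The source may hold more compounds than are shown below. What is called first, only, known or untested is meant among the compounds shown, and "the series" means these compounds.

Measured in a functional assay on MCF7 cells (Homo sapiens) for antiproliferative activity; on this read-out lower numbers stand for stronger inhibition and higher numbers for weaker inhibition:
- compound 1 `CCCCCn1c(Cc2cc(OC)c(OC)c(OC)c2)nc2c(N)nc(F)nc21`: 36300 nM
- compound 2 `CCCCCn1c(Cc2cc(OC)c(OC)c(OC)c2)nc2c(N)ncnc21`: 61700 nM
- compound 3 `CCCCn1c(Cc2cc(OC)c(OC)c(OC)c2)nc2c(N)nc(F)nc21`: 24000 nM

Compound 2 carries the highest of the three numbers. Its nearest neighbour is compound 1, reached by a 1.7-fold higher number from compound 1 to compound 2 (0.23 log units; within the scatter). Going by the values given here, its furthest is compound 3, whose value in this assay lies beyond the scatter from that of compound 2; no single-point step connects these two.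

Compound 4 `CCn1c(Cc2cc(OC)c(OC)c(OC)c2)nc2c(N)ncnc21` differs from compound 2 by hydrogen in place of propyl on a saturated chain carbon, two bonds along the chain from an aromatic nitrogen. Among the compounds with values here, the only measured step at the chain is a 1.5-fold lower number from compound 1 to compound 3 (0.18 log units; within the scatter), which shortens the chain by one carbon and stays within the scatter. The step to compound 4 shortens the same chain by three carbons, so it reaches further than anything measured here. The other measured step, a 1.7-fold higher number from compound 1 to compound 2 (0.23 log units; within the scatter), sits at an aromatic carbon and does not bear on the chain.

Within the data shown here, with one within-scatter chain step as the only guide, no step beyond the scatter is expected in this assay in either direction, though a larger shortening leaves the direction open. Compound 4 is estimated at 60000 nM, with a range from 15000 nM to 250000 nM, which means an expected step of a 1.0-fold lower number from compound 2 to compound 4 (0.01 log units; within the scatter).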

Compound 4, half-maximal inhibitory concentration: 79400 nM
Compound 4: middle estimate off by 1.3-fold (0.12 log units), on the low side, and the stated range covers the measured number.
By their numbers in this assay, from the lowest: compounds 3, 1, 2 and 4 (each within the scatter of the next, the first and the last beyond it).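

Working from the chain position in this assay, replacing pentyl with ethyl gives a 1.3-fold higher number from compound 2 to compound 4 (0.11 log units; within the scatter) and so stays inside the scatter, even though this change removes a propyl group of three carbons on a saturated chain carbon, two bonds along the chain from an aromatic nitrogen. The earlier chain step, a 1.5-fold lower number from compound 1 to compound 3 (0.18 log units; within the scatter), was read with fluoro on the aromatic carbon, while this one is read with hydrogen there, so the two within-scatter chain results now cover both forms of the shared core. No measurement shown here offers an explanation for this result.

The compounds shown leave open how a chain longer than pentyl, or a chain ending in an amine or a carboxylic acid, would read at this position in this assay and whether any such group would produce a step beyond the scatter. Also open, from the compounds shown here alone, is how an ethyl chain would read together with fluoro on the aromatic carbon, a pairing that would test whether the two sites can be read separately.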